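A few compounds are considered here, and "the series" means these few. Any claim that something is new, unique, unknown or untested is made for them only; others in the source may bear on it.

Measured compounds:
Compound 1 `COc1ccc2[nH]c(C)c(Cc3nn4c(Cc5ccc(OC)c(OC)c5)nnc4s3)c2c1` in a functional assay on the whole organism (strain Wistar Albino) for inhibition, with Rattus norvegicus as the target, read by paw edema, with a stated time of 4 h, at a dose of 20 mg/kg (on this read-out higher numbers stand for more inhibition at the one dose given (going by the name of the read-out) and lower numbers for less inhibition), gives 28.4%.
Compound 2 `COc1ccc(Cc2nnc3n2NC(c2ccc([N+](=O)[O-])o2)S3)cc1OC` in this assay gives 23.7%.

Compound 2 and compound 1 thus stand close together, their two readings lying within the usual scatter of each other, so neither can be called the stronger. Compound 3 `COc1ccc(Cc2nnc3n2NC(c2cccn2C)S3)cc1OC` has not yet been measured in this assay. It differs from compound 2 in one place: 1-methyl-1H-pyrrol-2-yl in place of 5-nitrofuran-2-yl on a saturated ring carbon. Going by the values given here, no measured pair in this set shows the effect of such a swap, so there is no basis for expecting a shift beyond the scatter. Compound 3 is therefore expected to give about 22%, between 8% and 38%, a step of a number 1.7 percentage points lower from compound 2 to compound 3 (within the scatter) expected to stay within the scatter.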

Compound 3, a percentage reported as inhibition, in the whole organism at one dose (the size of the read-out at that dose, not a potency): 19.9%
Estimate against measurement, compound 3: 2.1 percentage points above; measured number inside the range.
By their numbers in this assay, from the lowest: compounds 3, 2 and 1 (each within the scatter of the next).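

This first pair at this position gives a number 3.8 percentage points lower from compound 2 to compound 3 (within the scatter) in this assay, so compound 2 and compound 3 cannot be told apart. On this saturated ring carbon, a 5-nitrofuran-2-yl and a 1-methyl-1H-pyrrol-2-yl, with different counts of heavy atoms and hydrogen-bond acceptors, thus read alike at this one dose. Nothing available explains this result. Still open, from the compounds shown here alone, is whether a group of another kind on this carbon, such as a plain phenyl, a longer alkyl chain or an amine, would shift the reading beyond the scatter.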